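Chlorobenzyl isomers: from compound 1 to compound 3

The source may hold more compounds than are shown below. What is called first, only, known or untested is meant among the compounds shown, and "the series" means these compounds.

- compound 1 `CCCCc1[nH]c(=O)c(-c2nnc(Cc3cccc(Cl)c3)o2)c(O)c1-c1c(OC)cccc1OC` gives 88%
- compound 2 `COc1cccc(OC)c1-c1c(C2CC2)[nH]c(=O)c(-c2nnc(Cc3ccc(Cl)cc3)o2)c1O` gives 88%

In an ADME assay on microsomes from liver (Homo sapiens) for metabolic stability, read by mass spectrometry, using NADPH, with a stated time of 10 min (a higher number here means that more of the compound is left, a lower number that less of the compound is left), compound 1 stands level with compound 2, and the two values lie within the usual scatter. The next compound to be measured is compound 3 `CCCCc1[nH]c(=O)c(-c2nnc(Cc3ccccc3Cl)o2)c(O)c1-c1c(OC)cccc1OC`, which has the same atoms as compound 1, joined differently (2-chlorophenyl in place of 3-chlorophenyl on a saturated chain carbon bound to an aromatic carbon). The change is 2-chlorophenyl in place of 3-chlorophenyl on a saturated chain carbon bound to an aromatic carbon.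

Among the compounds with values here, no measured pair differs in one place, so no direct step is available to guide this comparison. The expectation rests only on compound 1 at 88% and compound 2 at 88%, and on the small size of the structural change. The estimated step of a number 4 percentage points lower from compound 1 to compound 3 (within the scatter) is small and downward, and is not expected to exceed the scatter. Compound 3 is expected at 84% within an estimated range (70% to 95%).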

Compound 3, percent of the compound remaining: 82%
The estimate for compound 3 lay 2 percentage points above the measured number, and the stated range covers the measured number.
By their numbers in this assay, from the lowest: compounds 3, 1 and 2 (each within the scatter of the next).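

In this assay, within the data shown here, 2-chlorophenyl in place of 3-chlorophenyl on a saturated chain carbon bound to an aromatic carbon gives a number 6 percentage points lower from compound 1 to compound 3 (within the scatter), the first reading of a change in one place. Compound 1 and compound 2 differ in more than one place, so they could not isolate this change; the present pair shows that, on this scaffold, 3-chlorobenzyl to 2-chlorobenzyl does not separate the two compounds in this read-out. No measurement available here bears on the basis of this result.

From the compounds shown here alone, it remains open whether a different group at this place, such as an amine-bearing benzyl, a carboxylic acid or a longer chain, would give a step beyond the scatter. A single pair also leaves open whether the same isomer change would read alike with another group on the core.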